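Ethoxy for Chloro on the Benzyl Ring of Compound 2

The source may report more compounds than this note shows. Statements on the series, on what has been measured and on what is new or still open speak of the compounds shown alone.

Measured compounds:
Compound 1, `CCc1ccccc1N(Cc1nnc(Cc2ccccc2)o1)S(=O)(=O)c1ccc(C)cc1`, 1000 nM
Compound 2, `CCc1ccccc1N(Cc1nnc(Cc2ccc(Cl)cc2)o1)S(=O)(=O)c1ccc(C)cc1`, 398 nM

In an assay on CHO cells for displacement of a labelled ligand from prostaglandin E2 receptor EP1 subtype (Homo sapiens) (a lower number here means a stronger inhibitor, a higher number a weaker inhibitor), compound 1 gives 1000 nM. Compound 2 stands at the lower of the two numbers, and the gap to compound 1 lies beyond the scatter: a 2.5-fold lower number from compound 1 to compound 2 (0.40 log units; beyond the scatter), brought by a chloro in place of hydrogen on an aromatic carbon.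

Compound 3, `CCOc1ccc(Cc2nnc(CN(c3ccccc3CC)S(=O)(=O)c3ccc(C)cc3)o2)cc1`, has not yet been measured. It differs from compound 2 in one place: ethoxy in place of chloro on an aromatic carbon.

Among the measured compounds shown here, the only measured step, a 2.5-fold lower number from compound 1 to compound 2 (0.40 log units; beyond the scatter), shows that adding a chloro at this position lowered the number modestly. For the measured compounds named here, no measured pair shows an ethoxy entering for a chloro, so there is no direct precedent for the size or direction of this change. The expectation is therefore cautious: a step of a 1.3-fold higher number from compound 2 to compound 3 (0.10 log units; within the scatter), within the scatter. Compound 3 is estimated at 500 nM, with a range from 150 nM to 1600 nM in this assay.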

Compound 3, half-maximal inhibitory concentration: 126 nM
Beside the measured number, compound 3's estimate is 4.0-fold (0.60 log units) above it; the measured number lies below the stated range.
By their numbers in this assay, from the lowest: compound 3; then compound 2; then compound 1.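

The step (a 3.2-fold lower number from compound 2 to compound 3 (0.50 log units; beyond the scatter)) shows that in this assay this position, para to a large group, has room for a further lower number than chloro gave, and that ethoxy reaches it while bringing more heavy atoms and a hydrogen-bond acceptor. Measured against hydrogen, the step is larger (a 7.9-fold lower number from compound 1 to compound 3 (0.90 log units; beyond the scatter)), so both groups shown at this place lower the number, ethoxy further than chloro. Nothing available explains why ethoxy gives the lower number.

Whether that lower number belongs to the oxygen of the ethoxy or to its carbon chain stays open, as the compounds shown include neither a methoxy nor a propoxy group at this place. Also open, as far as these compounds go, is how an amine or a carboxylic acid would fare here.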